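The source may hold more compounds than are shown below. What is called first, only, known or untested is meant among the compounds shown, and "the series" means these compounds.

Four compounds share one core and differ at two points. Compound 1 `Cc1ccc(Nc2nnc(Nc3nc(-c4ccc([N+](=O)[O-])cc4)cs3)s2)cc1` carries a 4-methylphenyl group and a nitro group; in a functional assay on the whole organism (strain albino) with Mus musculus as the target, in the maximal electroshock model, with a stated time of 0.5 h (on this read-out higher numbers stand for an effect only at larger amounts of compound and lower numbers for an effect already at smaller amounts), compound 1 gives 30 mg/kg. Compound 2 `COc1ccccc1Nc1nnc(Nc2nc(-c3ccc([N+](=O)[O-])cc3)cs2)s1` differs from compound 1 by 2-methoxyphenyl in place of 4-methylphenyl on a nitrogen on an aromatic ring, and in this assay compound 2 gives 300 mg/kg, so that a 10-fold higher number from compound 1 to compound 2 (1.00 log units; beyond the scatter). Compound 3 `Cc1ccc(Nc2nnc(Nc3nc(-c4ccccc4)cs3)s2)cc1` keeps the 4-methylphenyl group but differs from compound 1 by hydrogen in place of nitro on an aromatic carbon; in this assay compound 3 gives 100 mg/kg, and a 3.3-fold higher number from compound 1 to compound 3 (0.52 log units; beyond the scatter). Of the three measured values, compound 1 stands at the lowest number and compound 2 at the highest.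

Compound 4 `COc1ccccc1Nc1nnc(Nc2nc(-c3ccccc3)cs2)s1` has not yet been measured. It differs from compound 3 by 2-methoxyphenyl in place of 4-methylphenyl on a nitrogen on an aromatic ring. For the measured compounds named here, this is the same change, at the same place, as the one that leads from compound 1 to compound 2, and its effect on the read-out has been seen once. The core of compound 3 and compound 4 differs from that of compound 1 and compound 2 in the way described for compound 1 and compound 3.

Going by the values given here, on the strength of the single earlier step, compound 4 is expected to follow compound 3 with a step of a 10-fold higher number from compound 3 to compound 4 (1.00 log units; beyond the scatter), because the same replacement gave a 10-fold higher number from compound 1 to compound 2 (1.00 log units; beyond the scatter) in the same assay. Compound 4 is therefore estimated at 1000 mg/kg in this assay, with a plausible range from 300 mg/kg to 3000 mg/kg, and there is a real chance that only a limit rather than a number is reported.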

Compound 4, minimum effective dose: 100 mg/kg
Estimate against measurement, compound 4: 10-fold (1.00 log units) above; measured number outside the range, below it.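

For the compounds shown here, on the core without the nitro group, 2-methoxyphenyl in place of 4-methylphenyl on a nitrogen on an aromatic ring gives no change at the digits printed from compound 3 to compound 4 (within the scatter), so in this assay this change does not carry over from the core of compound 1 with the same size: the same change on two cores in this assay, a 10-fold higher number (1.00 log units; beyond the scatter) from compound 1 to compound 2 and no change at the digits printed (within the scatter) from compound 3 to compound 4, 10-fold (1.00 log units) apart, beyond the scatter of two such steps Read the other way round, hydrogen in place of nitro on an aromatic carbon gives a 3.0-fold lower number from compound 2 to compound 4 (0.48 log units; beyond the scatter), which runs opposite to its step on the core bearing 4-methylphenyl, so neither change has a single effect in these four compounds: the same change on two cores in this assay, a 3.3-fold higher number (0.52 log units; beyond the scatter) from compound 1 to compound 3 and a 3.0-fold lower number (0.48 log units; beyond the scatter) from compound 2 to compound 4, 10-fold (1.00 log units) apart, beyond the scatter of two such steps This shows that, within this set, the result of each change depends on the group at the other point, and that a step seen on one core cannot simply be transferred to the other; it does not show why the two cores differ, and it rests on only one pair of steps for each change, so it gives no general rule for the series.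

The compounds shown leave open how a plain phenyl group or a 4-chlorophenyl group on that nitrogen would behave on either core. They also leave open whether an amine or a carboxylic acid in place of nitro would follow compound 1 or compound 3 in its pattern.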